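Swapping Methoxy for Methylsulfanyl in a Cytotoxicity Series

This account rests on a few compounds, and the source may have more. Where it says the series, first, only, none or still open, it means among the compounds named here.

Compound 1 `CSc1ccc(CNc2nc([SeH])nc3ccccc23)cc1`: 45500 nM
Compound 2 `COc1ccc(CNc2nc(SC)nc3ccccc23)cc1`: 93700 nM

Both compounds were tested in a functional assay on HTB-54 cells (Homo sapiens) for cytotoxicity, read by MTT assay, with a stated time of 72 h; on this read-out higher numbers stand for weaker inhibition of growth and lower numbers for stronger inhibition of growth. Compound 2 stands at the higher of the two numbers, and compound 1 sits at a number that is lower by more than the usual scatter. Compound 3 `CSc1ccc(CNc2nc(SC)nc3ccccc23)cc1` has not been measured yet. It differs from compound 2 in one place: methylsulfanyl in place of methoxy on an aromatic carbon. Going by the values given here, no measured pair shows this exact exchange. Only a cautious expectation is possible: a small step downward, or none beyond the scatter. The estimated step in this assay from compound 2 to compound 3 is a 1.4-fold lower number from compound 2 to compound 3 (0.16 log units; within the scatter). Compound 3 is therefore expected to give about 65000 nM, within a range from 28000 nM to 150000 nM.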

Compound 3, concentration for 50% growth inhibition: 7220 nM
Compound 3: the middle estimate sits 9.0-fold (0.95 log units) above what was measured; the measured number lies below the stated range.
By their numbers in this assay, from the lowest: compound 3; then compound 1; then compound 2.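

In this assay, putting methylsulfanyl in place of methoxy on the aromatic carbon para to a large group gives a 13-fold lower number from compound 2 to compound 3 (1.11 log units; beyond the scatter), so exchanging oxygen for sulfur at this position makes a large difference. The second varied position also matters: a group of one carbon and one sulfur in place of one selenium atom gives a 6.3-fold lower number from compound 1 to compound 3 (0.80 log units; beyond the scatter). Nothing available here explains either step. Still open, going by these compounds, is how an amine or a longer chain, such as ethylsulfanyl, would behave at the first position.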